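The compounds below may be only part of what the source reports. "The series", "measured", "known", "first", "only" and "open" are said of these compounds alone.

Compound 1 `COc1ccc(-c2nc3cc(C(F)(F)F)ccc3[nH]2)c(OC)c1`, compound 2 `COc1ccc(-c2nc3cc(C(F)(F)F)ccc3[nH]2)cc1` and compound 3 `COc1cc(OC)cc(-c2nc3cc(C(F)(F)F)ccc3[nH]2)c1` were tested in an ADME assay on MDBK cells (Bos taurus) for cytotoxicity, read by MTT assay, with a stated time of 96 h; a lower number here means that less compound is tolerated, a higher number that more compound is tolerated. Compound 1 reached only a limit of the assay, > 100000 nM. Compound 2 likewise gave only a limit, > 100000 nM. Compound 3 also stopped at a limit, > 100000 nM. From compound 1 to compound 2 the change is hydrogen in place of methoxy on an aromatic carbon, and the step that the two limits leave unreadable from compound 1 to compound 2 cannot be read from the two limits. How the core of compound 1 and the core of compound 3 differ is not broken down here. Compound 4 `COc1cccc(-c2nc3cc(C(F)(F)F)ccc3[nH]2)c1` arises from compound 3 by hydrogen in place of methoxy on an aromatic carbon, the same kind of change, though the place is now meta to a large group instead of ortho to a large group. Because (the limit of > 100000 nM in this assay, at which 3 of the 3 values shown sit), the step of a number no higher from compound 3 to compound 4 (the limit leaves the size open) is expected to be small. Compound 4 is therefore expected to show about 100000 nM in this assay.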

Compound 4, half-maximal cytotoxic concentration: 28000 nM
Beside the measured number, compound 4's estimate is 3.6-fold (0.55 log units) above it, outside the stated range (below it).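

In this assay, hydrogen in place of methoxy on an aromatic carbon gives an at least 3.5-fold lower number from compound 3 to compound 4 (0.55 log units; beyond the scatter), which shows that this change can lower the number on this core. On these data alone, compound 3 stands at a limit of the assay, > 100000 nM, and the full size of the step stays open. The same change from compound 1 to compound 2 is a step that cannot be read, which leaves open whether the effect carries from one core to the other: the limit of > 100000 nM in this assay, at which 3 of the 4 values shown sit.

The compounds shown leave open how an amine, a hydroxyl group or a carboxylic acid would read in place of the methoxy group. They also leave open what a longer chain, such as butoxy, would do there.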